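This account rests on a few compounds, and the source may have more. Where it says the series, first, only, none or still open, it means among the compounds named here.

Measured compounds:
- compound 1, `CCN(Cc1cccs1)C(=O)COc1ccc(F)cc1`: 422 nM
- compound 2, `CCN(Cc1cccs1)C(=O)COc1ccc(C(F)(F)F)cc1`: 236 nM
- compound 3, `CCN(Cc1cccs1)C(=O)COc1ccc(Cl)cc1`: 39 nM

In an assay on HEK293 cells for agonist activity at transient receptor potential cation channel subfamily M member 8 (Homo sapiens), read by fluorescence and calcium flux, with a stated time of 15 min (a higher number here means that more compound is needed for the effect, a lower number that less compound is needed), compound 3 stands lowest of the three, with an 11-fold lower number from compound 1 to compound 3 (1.03 log units; beyond the scatter) and a 6.1-fold lower number from compound 2 to compound 3 (0.78 log units; beyond the scatter) both beyond the scatter; the remaining step, a 1.8-fold lower number from compound 1 to compound 2 (0.25 log units; within the scatter), is within it. The next compound is compound 4, `CCN(Cc1cccs1)C(=O)COc1ccc(C(=O)O)cc1`, which differs from compound 3 by carboxy in place of chloro on an aromatic carbon. All three measured steps change the group at this same place, so all bear on the move, but none of them introduces a hydrogen-bond donor or acceptor there, and the carboxy is new to the series. Given that every change away from chloro so far raised the number, compound 4 is expected to give a markedly higher number, a 130-fold higher number from compound 3 to compound 4 (2.11 log units; beyond the scatter), estimated at 5000 nM with a range of 1000 nM to 30000 nM.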

Compound 4, half-maximal effective concentration: "not active" (no number reported)
Compound 4: no number reported; there is nothing to compare the estimate with.
By their numbers in this assay, from the lowest: compound 3; then compounds 2 and 1 (each within the scatter of the next).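

In this assay, going by these compounds alone, compound 4 is recorded as "not active" without a number, so no step from compound 3 can be read. The compounds shown leave open whether any other hydrogen-bond donor at this place gives a measurable number. No measurement shown accounts for this result.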